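From Cyclohexyl to Methyl on the Carbonyl Carbon

This account rests on a few compounds, and the source may have more. Where it says the series, first, only, none or still open, it means among the compounds named here.

In a functional assay on HL-60 cells (Homo sapiens) for cytotoxicity, read by MTT assay, with a stated time of 72 h (on this read-out lower numbers stand for stronger inhibition and higher numbers for weaker inhibition), compound 2 (`O=C(Nc1nnc(-c2ccc(O)c(O)c2)s1)C1CCCCC1`) gives 8800 nM while compound 1 (`Cc1ccc(C(=O)Nc2nnc(-c3ccc(O)c(O)c3)s2)cc1`) gives 10500 nM on the same scale. The two lie within the scatter of each other. Compound 3 (`CC(=O)Nc1nnc(-c2ccc(O)c(O)c2)s1`) differs from compound 2 by one change: methyl in place of cyclohexyl on a carbonyl carbon. For the measured compounds named here, the only measured step at this place is a 1.2-fold lower number from compound 1 to compound 2 (0.08 log units; within the scatter) and it shows no change beyond the scatter, though no methyl analogue has yet been tested. In this assay the expected shift is therefore small, estimated as a 1.4-fold higher number from compound 2 to compound 3 (0.13 log units; within the scatter) and not beyond the scatter. Compound 3 is estimated at 12000 nM with 5000 nM to 30000 nM as the expected range.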

Compound 3, half-maximal inhibitory concentration: 42500 nM
Compound 3: the middle estimate sits 3.5-fold (0.55 log units) below what was measured; the measured number lies above the stated range.
By their numbers in this assay, from the lowest: compounds 2 and 1 (each within the scatter of the next); then compound 3.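

In this assay the position proves sensitive to this change: cyclohexyl and 4-methylphenyl could not be told apart, but methyl on the same carbonyl carbon gives clearly weaker inhibition (a 4.8-fold higher number from compound 2 to compound 3 (0.68 log units; beyond the scatter); a 4.0-fold higher number from compound 1 to compound 3 (0.61 log units; beyond the scatter)). Two quite different larger groups thus sit together, and only the single-carbon methyl stands apart. Nothing at hand explains this shift. The compounds shown leave open how the number changes between methyl and cyclohexyl, for instance with an ethyl group, a longer chain or a cyclopropyl ring on this carbonyl carbon.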